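This account rests on a few compounds, and the source may have more. Where it says the series, first, only, none or still open, it means among the compounds named here.

Compound 1 `CCOC(=O)c1sc(N/N=C/c2c(-c3ccc([N+](=O)[O-])cc3)[nH]c3ccccc23)nc1C` is one of three compounds examined in an ADME assay on MRC5 cells (Homo sapiens) for cytotoxicity, read by fluorescence, with a stated time of 24 h; on this read-out higher numbers stand for weaker inhibition and lower numbers for stronger inhibition. In this assay compound 1 gives 23500 nM and compound 3 `C=CCSc1nn2c(C=O)c(-c3ccccc3)nc2s1` gives 35400 nM, two values that lie within the scatter of each other. Compound 2 `CCC1S/C(=N\N=C\c2c(-c3ccccc3)[nH]c3ccccc23)NC1=O` is reported only as a limit, > 50000 nM. Compound 1 therefore has one numerical neighbour, and that neighbour cannot be told apart from it.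

The next compound, compound 4 `CCOC(=O)c1sc(N/N=C/c2c(-c3ccc(Cl)cc3)[nH]c3ccccc23)nc1C`, differs from compound 1 in one place: chloro in place of nitro on an aromatic carbon. In words, this is chloro in place of nitro on an aromatic carbon, para to a large group, so that 4-nitrophenyl becomes 4-chlorophenyl.

No measured pair among these compounds differs in one place, so the data offer no direct guide to the size of such a step in this assay. With compound 1 at 23500 nM as the only close reference, no step beyond the scatter is expected, and no direction is favoured. The step expected is a 1.1-fold higher number from compound 1 to compound 4 (0.04 log units; within the scatter). Compound 4 is estimated at 26000 nM, with an expected range from 12000 nM to 50000 nM.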

Compound 4, half-maximal inhibitory concentration: 25200 nM
For compound 4 the middle estimate is 1.0-fold (0.01 log units) above the measured one, within the range that was stated.
By their numbers in this assay, from the lowest: compounds 1, 4 and 3 (each within the scatter of the next). At a limit, above all of these: compound 2.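

In this assay, among these compounds, the exchange of a nitro group for a chloro group gives the first step that can be read between two compounds differing in one place: a 1.1-fold higher number from compound 1 to compound 4 (0.03 log units; within the scatter). Going from 4-nitrophenyl to 4-chlorophenyl removes a group with hydrogen-bond acceptors and puts in one with none, yet at this place on the aromatic ring the two compounds cannot be told apart by their numbers. The earlier compounds shown here offered no such pair, so this single comparison now shows that on the core of compound 1 this position accepts either of these two groups with no difference beyond the scatter.

Among the compounds shown here, compound 2 remains a limit of the assay and not a number, so it adds no step to this comparison: the limit of > 50000 nM in this assay, at which 1 of the 4 values shown sits. From the compounds shown here alone, whether an amine, a carboxylic acid or a longer chain at the same position would give a step beyond the scatter stays open, as does whether the exchange of nitro for chloro would read the same on another core.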